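Ethoxy on the distal ring of compound 2

The compounds below may be only part of what the source reports. "The series", "measured", "known", "first", "only" and "open" are said of these compounds alone.

Measured so far in a functional assay on CHO cells for agonist activity at Free fatty acid receptor 1 (Homo sapiens), read by FLIPR and calcium flux; a lower number here means that less compound is needed, a higher number that more compound is needed for the effect:
compound 1 `Cc1cccc(C)c1-c1cccc(COc2ccc(SCC(=O)O)cc2)c1`: 195 nM
compound 2 `Cc1cccc(C)c1-c1cccc(COc2ccc(S(=O)(=O)CC(=O)O)cc2)c1`: 66.1 nM
compound 3 `CO/N=C1\CC(CC(=O)O)c2ccc(OCc3cccc(-c4c(C)cc(OC)cc4C)c3)cc21`: > 1000 nM, a limit of the assay and not a number.

Compound 2 holds the lowest of the two numbers in this assay; its nearest neighbour is compound 1, and the step of a 3.0-fold lower number from compound 1 to compound 2 (0.47 log units; beyond the scatter) lies beyond the scatter. Compound 3 sits at the limit of > 1000 nM in this assay, at which 1 of the 3 values shown sits.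

Compound 4 `CCOc1cc(C)c(-c2cccc(COc3ccc(S(=O)(=O)CC(=O)O)cc3)c2)c(C)c1` has not been measured in this assay. It differs from compound 2 in one place: ethoxy in place of hydrogen on an aromatic carbon. For the measured compounds named here, the single measured step, a 3.0-fold lower number from compound 1 to compound 2 (0.47 log units; beyond the scatter), concerns the (carboxymethyl)sulfonyl end of the molecule and does not touch the ring that gains the ethoxy. Going by the values given here, compound 3 carries a methoxy on a ring of that kind, but on a different core, and no step joining it to compound 2 is available. Among the compounds with values here, no measured step therefore bears directly on the change, and the expectation rests on the change itself being small. In this assay compound 4 is expected to show a step of a 1.5-fold lower number from compound 2 to compound 4 (0.17 log units; within the scatter) that stays within the scatter. The estimate for compound 4 is 45 nM, with a range from 12 nM to 160 nM.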

Compound 4, half-maximal effective concentration: 63.1 nM
Compound 4: middle estimate off by 1.4-fold (0.15 log units), on the low side; the measured number falls inside the stated range.
By their numbers in this assay, from the lowest: compounds 4 and 2 (each within the scatter of the next); then compound 1. At a limit, above all of these: compound 3.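

In this assay, ethoxy in place of hydrogen on the aromatic carbon meta to two methyl groups and para to a large group gives a 1.0-fold lower number from compound 2 to compound 4 (0.02 log units; within the scatter), so this position accepts ethoxy with no step beyond the scatter. For the compounds shown here, the only earlier step between measured compounds, a 3.0-fold lower number from compound 1 to compound 2 (0.47 log units; beyond the scatter), concerned the (carboxymethyl)sulfonyl end of the molecule, so this is the first reading of a change on the ring that carries the two methyl groups. Nothing measured here bears on why the step stays within the scatter.

Going by these compounds alone, compound 3 stands at > 1000 nM, a limit of the assay and not a number, and with its different core it offers no step that can be read against this position. Still open, on these data alone, is whether the position accepts groups of another kind, such as an amine or a longer alkoxy chain, and whether ethoxy gives the same small step with the (carboxymethyl)sulfanyl end of compound 1.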